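A few compounds are considered here, and "the series" means these few. Any claim that something is new, unique, unknown or untested is made for them only; others in the source may bear on it.

Compound 1 `C=CC(=O)N1CC[C@H](N2C(=O)N(Cc3ccccc3)Cc3cnc(Nc4ccc(N5CCN(C)CC5)cc4OC)nc32)C1` is the starting point. In a physicochemical assay for solubility, read by HPLC, in phosphate buffer, measured as thermodynamic solubility, with a stated time of 24 h, at pH 6.8 (on this read-out lower numbers stand for lower solubility and higher numbers for higher solubility), compound 1 gives 107 ug/mL, the lower of the two numbers available, while compound 2 `C=CC(=O)N1CC[C@H](N2C(=O)N(c3ccccc3)Cc3cnc(Nc4ccc(N5CCN(C)CC5)cc4OC)nc32)C1` gives 1540 ug/mL; the step of a 14-fold higher number from compound 1 to compound 2 (1.16 log units; beyond the scatter) comes from phenyl in place of benzyl on an amide-type nitrogen in a ring. Compound 3 `C=CC(=O)NC1CCC(N2C(=O)N(Cc3ccccc3)Cc3cnc(Nc4ccc(N5CCN(C)CC5)cc4OC)nc32)CC1` is not yet measured. It differs from compound 1 by 4-((vinylcarbonyl)amino)cyclohexyl in place of 1-(vinylcarbonyl)pyrrolidin-3-yl on an amide-type nitrogen in a ring. For the measured compounds named here, no measured step touches this position: the one step available, a 14-fold higher number from compound 1 to compound 2 (1.16 log units; beyond the scatter), changes the benzyl group instead, so it offers no guide to the size or direction of the present change. With nothing to build on, the expectation for compound 3 in this assay is a number close to that of compound 1, a step of a 1.2-fold lower number from compound 1 to compound 3 (0.08 log units; within the scatter) that stays within the scatter. The estimate for compound 3 is 90 ug/mL, with a range from 30 ug/mL to 300 ug/mL.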

Compound 3, solubility: 18.8 ug/mL
The estimate for compound 3 lay 4.8-fold (0.68 log units) above the measured number; measured number outside the range, below it.
By their numbers in this assay, from the lowest: compound 3; then compound 1; then compound 2.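

In this assay, this swap on the amide-type nitrogen in a ring brings a 5.7-fold lower number from compound 1 to compound 3 (0.76 log units; beyond the scatter), so this position affects the read-out, which the earlier benzyl-to-phenyl step could not show. The swap changes several features at once: 4-((vinylcarbonyl)amino)cyclohexyl has a six-membered ring of carbon only, more heavy atoms and a hydrogen-bond donor, and it lacks the defined stereocentre of 1-(vinylcarbonyl)pyrrolidin-3-yl. No measurement at hand bears on the reason for the lower number.

This single step cannot separate the contributions of those features. It also leaves open what a piperidine ring carrying the same vinylcarbonyl group, or a cyclohexyl ring bearing an amine in place of the vinylcarbonyl amide, would give at this position.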